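The source may hold more compounds than are shown below. What is called first, only, known or untested is meant among the compounds shown, and "the series" means these compounds.

Measured so far:
compound 1, `CCCn1c(-c2ccco2)nc2c(N)nc(NCc3ccccc3)nc21`, 4610 nM
compound 2, `CCCn1cnc2c(NCCCc3ccccc3)ncnc21`, > 30000 nM

Compound 2 stands at the edge of what a functional assay on CHO cells for antagonist activity at adenosine receptor A2b (Homo sapiens) (on this read-out lower numbers stand for stronger inhibition and higher numbers for weaker inhibition), reports. Its value for compound 2, > 30000 nM, is a limit of the assay and not a number, as recorded in the limit of > 30000 nM in this assay, at which 1 of the 2 values shown sits. Compound 1 carries a furan-2-yl group on the shared core and gives a number in this assay, 4610 nM. Among the measured compounds shown here, no single step connects compound 1 and compound 2, as they differ in more than one place; the two values show only that compound 1 returns a number while compound 2 sits at the limit.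

Compound 3, `CCCn1c(-c2ccco2)nc2c(NCCCc3ccccc3)ncnc21`, is not yet measured. It differs from compound 2 in one place: furan-2-yl in place of hydrogen on an aromatic carbon. The same group is present in compound 1.

In this assay the step from compound 2 to compound 3 is expected to move toward stronger inhibition, probably beyond the usual scatter, though with compound 2 at a limit the size is uncertain. The expected step is an at least 2.5-fold lower number from compound 2 to compound 3 (0.39 log units; beyond the scatter). Compound 3 is estimated at 12000 nM, with a range from 3000 nM to 60000 nM.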

Compound 3, inhibition constant: 1870 nM
Estimate against measurement, compound 3: 6.4-fold (0.81 log units) above, outside the stated range (below it).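

In this assay, furan-2-yl in place of hydrogen on an aromatic carbon, between two ring nitrogen atoms and next to the ring atom that bears a propyl group, gives an at least 16-fold lower number from compound 2 to compound 3 (1.20 log units; beyond the scatter). Compound 1 and compound 2 differ in more than one place, so their values could not tie any change in inhibition to this position; this pair differs only in furan-2-yl and shows that this single change takes the series from a limit of the assay to a measured number. The printed size is a minimum and not an exact step, because compound 2 stands at a limit: the limit of > 30000 nM in this assay, at which 1 of the 3 values shown sits.

Only hydrogen and furan-2-yl are shown at this carbon, so it remains open whether another group there, such as phenyl, thiophen-2-yl or methyl, would give a comparable step. Compound 1 and compound 3 differ in more than one place, which leaves the separate contributions of their other substituents unresolved, as it does the effect of a longer chain in place of the propyl group.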